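Ortho methyl for ortho chloro on the aryl triazole

The compounds below may be only part of what the source reports. "The series", "measured", "known", "first", "only" and "open" are said of these compounds alone.

Compound 1 `Clc1ccccc1-n1cc(CSc2nc3ccccc3s2)nn1` gives 83.3% in a functional assay on the whole organism (strain Albino Wistar) for inhibition, with Rattus norvegicus as the target, read by paw edema, with stated times of 1 h and 3 h, at a dose of 10 mg/kg by the oral route; on this read-out lower numbers stand for less inhibition and higher numbers for more inhibition at the one dose given (going by the name of the read-out). Compound 2 `Clc1cccc(-n2cc(CSc3nc4ccccc4s3)nn2)c1` gives 35% and compound 3 `Brc1ccc(-n2cc(CSc3nc4ccccc4s3)nn2)cc1` gives 75%. Against compound 1 the steps are a number 48.3 percentage points lower from compound 1 to compound 2 (beyond the scatter) and a number 8.3 percentage points lower from compound 1 to compound 3 (within the scatter), so compound 1 sits apart from compound 2 but not from compound 3. Compound 4 `Cc1ccccc1-n1cc(CSc2nc3ccccc3s2)nn1` differs from compound 1 by methyl in place of chloro on an aromatic carbon. No measured step swaps a group at a fixed position; the steps shown move a halogen around the ring, and the one that keeps the same-sized halogen in a new position, a number 8.3 percentage points lower from compound 1 to compound 3 (within the scatter), stays within the scatter. The step of a number 8.3 percentage points lower from compound 1 to compound 4 (within the scatter) is therefore expected to be small. Compound 4 is estimated at 75%, within 55% to 90%.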

Compound 4, a percentage reported as inhibition, in the whole organism at one dose (the size of the read-out at that dose, not a potency): 47.3%
Compound 4: the middle estimate sits 27.7 percentage points above what was measured; measured number outside the range, below it.
By their numbers in this assay, from the lowest: compound 2; then compound 4; then compounds 3 and 1 (each within the scatter of the next).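

Chloro and methyl are not interchangeable on this aromatic carbon in this assay, although each is a single heavy atom (a number 36 percentage points lower from compound 1 to compound 4 (beyond the scatter)). The earlier compounds shown here varied only the halogen and its place, whereas the 2-methylphenyl group now stands apart from both other aryl groups (a number 27.7 percentage points lower from compound 3 to compound 4 (beyond the scatter); a number 12.3 percentage points higher from compound 2 to compound 4 (beyond the scatter)). Nothing available bears on the reason for this gap.

From the compounds shown here alone, what an amine or a methoxy group would give on the same aromatic carbon stays open. Compound 2 and compound 3 differ in both halogen and place, so these two changes remain unseparated.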